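The source may report more compounds than this note shows. Statements on the series, on what has been measured and on what is new or still open speak of the compounds shown alone.

Of the compounds shown here, three have so far been measured in an ADME assay on RD cells (Homo sapiens) for cytotoxicity, read by MTT assay, with a stated time of 3 days; a lower number here means that less compound is tolerated, a higher number that more compound is tolerated. Compound 1, `CCC[C@H](CCn1cncn1)c1ccc(F)cc1`, gives 38.4 ug/mL. Compound 2, `CCC[C@H](CCn1cncn1)c1ccc(C)cc1`, gives 47.2 ug/mL in this assay. Compound 3, `CCCC[C@H](CCn1cncn1)c1ccc(F)cc1`, gives 35.2 ug/mL in this assay, and its value sits within the scatter of both other compounds.

Compound 2 differs from compound 1 by methyl in place of fluoro on an aromatic carbon, and this change produced a 1.2-fold higher number from compound 1 to compound 2 (0.09 log units; within the scatter). Compound 3 differs from compound 1 by methyl in place of hydrogen on a saturated chain carbon, four bonds along the chain from an aromatic carbon, which is also how the two cores in this set differ; that change produced a 1.1-fold lower number from compound 1 to compound 3 (0.04 log units; within the scatter). Neither step rose above the scatter of the method.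

Compound 4, `CCCC[C@H](CCn1cncn1)c1ccc(C)cc1`, has not yet been measured in this assay. It differs from compound 3 by methyl in place of fluoro on an aromatic carbon, which is the same change already seen between compound 1 and compound 2, made on the core of compound 3 instead of the core of compound 1. The same change therefore appears twice among these four compounds.

The expectation for compound 4 rests on two observations. Because a 1.2-fold higher number from compound 1 to compound 2 (0.09 log units; within the scatter) remained within the scatter, the change itself seems to move the number little. Because a 1.1-fold lower number from compound 1 to compound 3 (0.04 log units; within the scatter) also remained within the scatter, the core of compound 3 appears to behave much like the core of compound 1. The step from compound 3 to compound 4 is thus expected to be small, estimated as a 1.2-fold higher number from compound 3 to compound 4 (0.08 log units; within the scatter). Compound 4 is estimated at 42 ug/mL, with an expected range from 28 ug/mL to 62 ug/mL.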

Compound 4, half-maximal cytotoxic concentration: 26.5 ug/mL
Beside the measured number, compound 4's estimate is 1.6-fold (0.20 log units) above it, and the stated range ends above it.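

In this assay, methyl in place of fluoro on an aromatic carbon gave a 1.3-fold lower number from compound 3 to compound 4 (0.12 log units; within the scatter), and this step does not separate from the same change on the core of compound 1: the same change on two cores in this assay, a 1.2-fold higher number (0.09 log units; within the scatter) from compound 1 to compound 2 and a 1.3-fold lower number (0.12 log units; within the scatter) from compound 3 to compound 4, 1.6-fold (0.21 log units) apart, within the scatter of two such steps. The added chain methyl reads the same way, giving a 1.8-fold lower number from compound 2 to compound 4 (0.25 log units; within the scatter), and this step also agrees with its earlier counterpart: the same change on two cores in this assay, a 1.1-fold lower number (0.04 log units; within the scatter) from compound 1 to compound 3 and a 1.8-fold lower number (0.25 log units; within the scatter) from compound 2 to compound 4, 1.6-fold (0.21 log units) apart, within the scatter of two such steps. Among these compounds, the four compounds therefore give no sign that either change depends on the core carrying it, but every step lies within the scatter, so they show only that these two changes stay small on these two cores and not that their size is truly the same or that a larger change would carry over in the same way.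

On these data alone, it remains open whether another group on that aromatic carbon, such as chloro, methoxy or trifluoromethyl, would move the number beyond the scatter. As far as these compounds go, it is equally open whether a longer chain than that of compound 3, or an amine or a carboxylic acid on the chain, would leave the number as little changed.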